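This account rests on a few compounds, and the source may have more. Where it says the series, first, only, none or still open, it means among the compounds named here.

Compound 1: `COc1cccc2c1c(NS(=O)(=O)c1ccc(Cl)c(Cl)c1)nn2Cc1cccc(CNC(=O)C(C)(C)O)c1`, 398 nM in a functional assay on CHO cells for antagonist activity at C-C chemokine receptor type 4 (Homo sapiens), read by GTPgammaS binding; a lower number here means a stronger inhibitor, a higher number a weaker inhibitor.
Compound 2: `COc1cccc2c1c(NS(=O)(=O)c1cccc(Cl)c1)nn2Cc1cccc(CNC(=O)C(C)(C)O)c1`, 50.1 nM in this assay.

Compound 2 gives the lowest of the two numbers in this assay; its nearest neighbour is compound 1, with the step of a 7.9-fold lower number from compound 1 to compound 2 (0.90 log units; beyond the scatter) when a chloro is removed from the sulfonyl-bearing ring. Compound 3, `COc1cccc2c1c(NS(=O)(=O)c1cccc(Cl)c1Cl)nn2Cc1cccc(CNC(=O)C(C)(C)O)c1`, reverses that idea at another spot: chloro in place of hydrogen on an aromatic carbon. For the measured compounds named here, the one measured step shows that a second chloro on this ring raised the number, so a rise is expected here too, estimated as a 3.0-fold higher number from compound 2 to compound 3 (0.48 log units; beyond the scatter). Compound 3 is thus expected to give about 150 nM in this assay, within 50 nM to 500 nM.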

Compound 3, half-maximal inhibitory concentration in the C-C chemokine receptor type 4 assay: 398 nM
Beside the measured number, compound 3's estimate is 2.7-fold (0.42 log units) below it, within the range that was stated.
By their numbers in the C-C chemokine receptor type 4 assay, from the lowest: compound 2; then compounds 1 and 3 (each within the scatter of the next).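

Compound 3 shows that the penalty for a second chloro is not confined to the 3,4-dichlorophenyl pattern of compound 1: in the C-C chemokine receptor type 4 assay, placing it ortho to a chloro group gives a 7.9-fold higher number from compound 2 to compound 3 (0.90 log units; beyond the scatter). The two dichlorophenyl isomers are indistinguishable, with no change at the digits printed from compound 1 to compound 3 (within the scatter). In a physicochemical assay for solubility, read by chemiluminescence, measured as kinetic solubility (a lower number here means a less soluble compound, a higher number a more soluble compound), compound 2 gives >= 198 ug/mL as a limit of the assay. In the physicochemical assay compound 3 gives 157 ug/mL as a measured value. The size of any difference between these two compounds cannot be read: the limit of >= 198 ug/mL in the physicochemical assay, at which 1 of the 2 values shown sits.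

The compounds shown leave open whether the loss is specific to chloro or would also follow a fluoro or methyl group on that carbon.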